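Methoxy to Iodo on a Series That Only Shows Limits

The source may hold more compounds than are shown below. What is called first, only, known or untested is meant among the compounds shown, and "the series" means these compounds.

Compound 2 `COc1ccc(N2C(=O)/C(=C/c3ccc(OCc4ccc(C(=O)O)cc4)cc3)SC2=S)cc1` was tested in an assay on isolated protein for inhibition of Apoptosis regulator Bcl-2 (Homo sapiens), read by fluorescence polarization; a lower number here means a stronger inhibitor, a higher number a weaker inhibitor. In this assay compound 2 gives > 10000 nM, which is a limit of the assay rather than a number. For the measured compounds named here, the only measured step, a step that the two limits leave unreadable from compound 1 to compound 2, cannot be sized. Its partner compound 1 `Cc1ccc(N2C(=O)/C(=C/c3ccc(OCc4ccc(C(=O)O)cc4)cc3)SC2=S)cc1` gives > 10000 nM in this assay, again a limit. Both values therefore rest on (the limit of > 10000 nM in this assay, at which 2 of the 2 values shown sit).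

Compound 3 `O=C(O)c1ccc(COc2ccc(/C=C3\SC(=S)N(c4ccc(I)cc4)C3=O)cc2)cc1` differs from compound 2 by iodo in place of methoxy on an aromatic carbon. No readable step bears on this change, so there is no ground to expect a step beyond the scatter in either direction; the measured values give only a floor of weakness. Compound 3 is thus expected to sit near 20000 nM, within 8000 nM to 60000 nM, most likely again reported as a limit. The expected step from compound 2 to compound 3 is estimated at a step that the limit leaves unreadable from compound 2 to compound 3.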

Compound 3, inhibition constant: 4300 nM
The estimate for compound 3 lay 4.7-fold (0.67 log units) above the measured number, outside the stated range (below it).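

In this assay the position on the aromatic ring para to a large group now gives a readable change, with iodo in place of methoxy giving an at least 2.3-fold lower number from compound 2 to compound 3 (0.36 log units; beyond the scatter) and iodo in place of methyl giving an at least 2.3-fold lower number from compound 1 to compound 3 (0.36 log units; beyond the scatter) on the same core. Of the three groups shown at this position, only iodo yields a measured number, and the step between the methyl and methoxy compounds still cannot be read. Both readable steps are only lower bounds, because each starts from a limit of the assay rather than a number: the limit of > 10000 nM in this assay, at which 2 of the 3 values shown sit.

As far as these compounds go, the true size of either step remains unknown, as the starting compounds have no exact values. From the compounds shown here alone, whether bromo or chloro at this position would also give a measured number, and how an amine there would read, stays open.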